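Aryl Exchange on an Aromatic Nitrogen

The source may hold more compounds than are shown below. What is called first, only, known or untested is meant among the compounds shown, and "the series" means these compounds.

compound 1 `Cc1ccc(-n2nc(-c3ccc(C(F)(F)F)cc3O)nc2-c2ccccc2O)cc1` — 94.1%
compound 2 `Oc1cc(C(F)(F)F)ccc1-c1nc(-c2ccccc2O)n(-c2ccccc2F)n1` — 86.6%

In a functional assay on PC-12 cells (Rattus norvegicus) for cytotoxicity, read by MTT assay, with stated times of 2 h and 24 h, tested at 5 uM (a higher number here means a stronger effect of the compound at the concentration tested, a lower number a weaker effect), compound 1 gives 94.1% and compound 2 gives 86.6%; compound 2 stands lowest of the two numbers, with compound 1 within the scatter of it. Compound 3 `Cc1cc(C)cc(-n2nc(-c3ccc(C(F)(F)F)cc3O)nc2-c2ccccc2O)c1` differs from compound 2 in 3,5-dimethylphenyl in place of 2-fluorophenyl on an aromatic nitrogen. Among the compounds with values here, the one measured step that bears on this, an exchange of the aryl group on the same aromatic nitrogen, is a number 7.5 percentage points lower from compound 1 to compound 2 (within the scatter). No shift beyond the scatter is therefore expected; the step expected is a number 2.4 percentage points higher from compound 2 to compound 3 (within the scatter). Compound 3 is estimated at 89%, between 77% and 99%.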

Compound 3, a percentage reported as activity, at one concentration (the size of the read-out at that concentration, not a potency): 102%
The estimate for compound 3 lay 13 percentage points below the measured number; the whole stated range lies below it.
By their numbers in this assay, from the lowest: compounds 2, 1 and 3 (each within the scatter of the next, the first and the last beyond it).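

On this aromatic nitrogen, the aryl exchange now gives a step beyond the scatter in this assay: a number 15.4 percentage points higher from compound 2 to compound 3 (beyond the scatter), with 3,5-dimethylphenyl in place of 2-fluorophenyl. The exchange of 4-methylphenyl for 3,5-dimethylphenyl gives a number 7.9 percentage points higher from compound 1 to compound 3 (within the scatter), so only this one of the two new exchanges separates. Nothing measured here explains the larger step.

The compounds shown do not separate the loss of fluorine from the gain of the methyl groups. They also leave open how an aryl group carrying an amine or a carboxylic acid would read at this position.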